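Cytotoxicity at the limit: compound 2 to compound 4

The compounds below may be only part of what the source reports. "The series", "measured", "known", "first", "only" and "open" are said of these compounds alone.

Compound 2 (`C=C[C@@](C)(/C=C/c1ccc(Nc2ccc(F)cc2)cc1)CCC=C(C)C`) gives > 36600 nM in an ADME assay on BJ cells (Homo sapiens) for cytotoxicity, with a stated time of 72 h (on this read-out lower numbers stand for an effect already at smaller amounts and higher numbers for an effect only at larger amounts of compound), as a limit and not a number. Compound 1 (`C=C[C@@](C)(/C=C/c1ccc(Nc2ccc(OC)c(F)c2)cc1)CCC=C(C)C`) gives > 36600 nM as a limit too. Compound 3 (`C=C[C@@](C)(/C=C/c1ccc(Nc2ccc(C(F)(F)F)cc2)cc1)CCC=C(C)C`) gives > 36600 nM as a limit too. The series therefore rests on the limit of > 36600 nM in this assay, at which 3 of the 3 values shown sit, and holds no number yet. The measured steps are a step that the two limits leave unreadable from compound 1 to compound 2 and a step that the two limits leave unreadable from compound 2 to compound 3 and neither offers a size to carry over. Compound 4 (`C=C[C@@](C)(/C=C/c1ccc(-c2ccc(F)cc2)cc1)CCC=C(C)C`) differs from compound 2 by 4-fluorophenyl in place of (4-fluorophenyl)amino on an aromatic carbon and neither measured step removes the nitrogen. The expected change is a step that the limit leaves unreadable from compound 2 to compound 4 in this assay and no step beyond the scatter is expected. The estimate for compound 4 is 40000 nM with an expected range from 15000 nM to 80000 nM and another limit is the likely report.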

Compound 4, half-maximal effective concentration: > 36600 nM
Compound 4 gave a limit, no number; the forecaster's own chance of this, stated with the estimate: 80%; the middle value lies beyond the limit too.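

Compound 2 and compound 4 both stand only as limits, so no step between them can be read: the limit of > 36600 nM in this assay, at which 4 of the 4 values shown sit.

The compounds shown leave open how far any of the four lies beyond that limit, and whether removing the nitrogen changes cytotoxicity at all.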